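The source may hold more compounds than are shown below. What is called first, only, known or untested is meant among the compounds shown, and "the series" means these compounds.

Within the data shown here, in a functional assay on HOP-92 cells (Homo sapiens) for inhibition, read by sulforhodamine B assay, with a stated time of 48 h (a higher number here means a weaker inhibitor of growth, a lower number a stronger inhibitor of growth), compound 1 (`O=C(Nc1cccc(-n2cc(-c3ccncc3)c(-c3ccc(Cl)c(O)c3)n2)c1)Nc1cccc(C(F)(F)F)c1`) gives 509 nM and stands highest of the two numbers so far. Compound 2 (`COc1cc(-c2nn(-c3cccc(NC(=O)Nc4ccc(Cl)c(Cl)c4)c3)cc2-c2ccncc2)ccc1Cl`), which carries 4-chloro-3-methoxyphenyl, gives 151 nM and lies lower, beyond the scatter. Compound 3 (`COc1cc(-c2nn(-c3cccc(NC(=O)Nc4cccc(C(F)(F)F)c4)c3)cc2-c2ccncc2)ccc1Cl`) differs from compound 1 by methyl in place of hydrogen on an oxygen on an aromatic ring, hydroxy to methoxy. Among the measured compounds shown here, no measured pair isolates this change, and compound 2 is the only guide. In this assay a modest step toward a lower number is expected (a 2.1-fold lower number from compound 1 to compound 3 (0.33 log units; beyond the scatter)). Compound 3 is estimated at 240 nM (expected range 90 nM to 600 nM).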

Compound 3, concentration for 50% growth inhibition: 557 nM
Compound 3: the middle estimate sits 2.3-fold (0.37 log units) below what was measured; the measured number falls inside the stated range.
By their numbers in this assay, from the lowest: compound 2; then compounds 1 and 3 (each within the scatter of the next).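

In this assay hydroxy to methoxy on the aromatic ring reads as no real change with 3-(trifluoromethyl)phenyl on the amide-type nitrogen (a 1.1-fold higher number from compound 1 to compound 3 (0.04 log units; within the scatter)), so this oxygen accepts methyl in place of hydrogen in this setting. With 4-chloro-3-methoxyphenyl held fixed, 3-(trifluoromethyl)phenyl in place of 3,4-dichlorophenyl on the amide-type nitrogen gives a step beyond the scatter (a 3.7-fold higher number from compound 2 to compound 3 (0.57 log units; beyond the scatter)). No measurement at hand bears on the origin of either step.

Open, going by these compounds, is whether hydroxy and methoxy also read alike with 3,4-dichlorophenyl on that nitrogen. Also open, on these data alone, is how an ethyl group or a chain ending in an amine would read on the same oxygen.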